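This account rests on a few compounds, and the source may have more. Where it says the series, first, only, none or still open, it means among the compounds named here.

Compound 1 `CCOC(=O)c1ccc(-c2nn(Cc3cccc(F)c3)c3ccccc23)cc1`: > 10000 nM
Compound 2 `CCOC(=O)c1ccc(-c2nn(Cc3ccccc3OC)c3ccccc23)cc1`: > 10000 nM
Compound 3 `CCCn1nc(-c2ccc(C(=O)OCC)cc2)c2ccccc21`: > 10000 nM

In a functional assay on cells (Platelet, Homo sapiens) for inhibition (on this read-out higher numbers stand for weaker inhibition and lower numbers for stronger inhibition), compound 3 gives > 10000 nM, which is a limit and not a number. The whole set stands at one mark: the limit of > 10000 nM in this assay, at which 3 of the 3 values shown sit.

Compound 4 `CCCCn1nc(-c2ccc(C(=O)OCC)cc2)c2ccccc21` lengthens the propyl chain of compound 3 to butyl: methyl in place of hydrogen on a saturated chain carbon, three bonds along the chain from an aromatic nitrogen.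

The measured steps bear on this only loosely: a step that the two limits leave unreadable from compound 1 to compound 2, a step that the two limits leave unreadable from compound 1 to compound 3 and a step that the two limits leave unreadable from compound 2 to compound 3. None of them gives a size or a direction, so no step beyond the scatter is expected. The expected step is a step that the limit leaves unreadable from compound 3 to compound 4.

For compound 4 the estimate is 12000 nM, with an expected range from 4000 nM to 30000 nM.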

Compound 4, half-maximal inhibitory concentration: > 10000 nM
Compound 4 gave a limit, no number (the forecaster's own chance of this, stated with the estimate: 85%); the middle value lies beyond the limit too.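

In this assay, compound 4 gives only a limit, as do compounds 1, 2 and 3, so no step among these compounds can be read: the limit of > 10000 nM in this assay, at which 4 of the 4 values shown sit.

The compounds shown leave open whether any chain or group at this place gives a measurable inhibition in this assay.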